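A Piperidine Amide Replaces the Aminoethyl Amide

The compounds below may be only part of what the source reports. "The series", "measured", "known", "first", "only" and "open" are said of these compounds alone.

Of the compounds shown here, three sharing one core have been tested in a functional assay on MCF7 cells (Homo sapiens) for cytotoxicity, read by MTT assay, with a stated time of 24 h; a lower number here means a stronger inhibitor, a higher number a weaker inhibitor. Compound 1 `CNC(=O)Cn1nc(N)c2c(C(F)(F)F)cc(-c3ccccc3)nc21` gives 11800 nM in this assay. Compound 2 `NNC(=O)Cn1nc(N)c2c(C(F)(F)F)cc(-c3ccccc3)nc21` gives 35400 nM, and compound 3 `NCCNC(=O)Cn1nc(N)c2c(C(F)(F)F)cc(-c3ccccc3)nc21` gives 42900 nM, the highest of the three numbers, though compound 2 sits within the scatter of it. The two steps that reach beyond the scatter both introduce an additional nitrogen into the amide side chain: a 3.0-fold higher number from compound 1 to compound 2 (0.48 log units; beyond the scatter) and a 3.6-fold higher number from compound 1 to compound 3 (0.56 log units; beyond the scatter). Between the two amino-bearing compounds the step is small, a 1.2-fold higher number from compound 2 to compound 3 (0.08 log units; within the scatter).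

Compound 4 `Nc1nn(CC(=O)N2CCCCC2)c2nc(-c3ccccc3)cc(C(F)(F)F)c12` differs from compound 3 in a single place: piperidin-1-yl in place of (2-aminoethyl)amino on a carbonyl carbon. The group that leaves carries the two hydrogen-bond donors and the acceptor that the methyl amide of compound 1 lacks, and the group that enters carries none. Because compound 1 gives 11800 nM while compound 3 gives 42900 nM, removing the aminoethyl side chain is expected to move the number back toward that of compound 1, so a modest fall is expected, a 2.9-fold lower number from compound 3 to compound 4 (0.46 log units; beyond the scatter). Compound 4 is therefore estimated to give 15000 nM in this assay, most likely between 5000 nM and 45000 nM.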

Compound 4, half-maximal inhibitory concentration: 4100 nM
Beside the measured number, compound 4's estimate is 3.7-fold (0.56 log units) above it; measured number outside the range, below it.
By their numbers in this assay, from the lowest: compound 4; then compound 1; then compounds 2 and 3 (each within the scatter of the next).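

In this assay, within the data shown here, piperidin-1-yl is the first group on this carbonyl carbon to take the number below that of the methylamino group of compound 1 (a step of a 2.9-fold lower number from compound 1 to compound 4 (0.46 log units; beyond the scatter)), so the methyl amide does not mark the low end of what this position allows. Against the amino-bearing side chains the same exchange counts for much more, with a 10-fold lower number from compound 3 to compound 4 (1.02 log units; beyond the scatter) and an 8.6-fold lower number from compound 2 to compound 4 (0.94 log units; beyond the scatter), which shows that the position spans a far wider range of numbers than the first three compounds revealed, and that a six-membered ring with 0 hydrogen-bond donors is tolerated there. No measurement at hand accounts for this result.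

Compound 4 loses the amide hydrogen and gains a ring in the same change, so the compounds shown do not tell which of the two goes with the lower number. A dimethylamino amide, which has no amide hydrogen and no ring, and a pyrrolidin-1-yl or morpholin-4-yl amide, which vary the ring, would separate these two features.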